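Trading 2,4-Dichlorophenyl for Pyridin-3-yl on the Sulfonyl Sulfur

The source may report more compounds than this note shows. Statements on the series, on what has been measured and on what is new or still open speak of the compounds shown alone.

Measured so far in a functional assay on DLD-1 cells (Homo sapiens) for antiproliferative activity, read by CellTiter-Glo, with a stated time of 72 h; a lower number here means a stronger inhibitor, a higher number a weaker inhibitor:

compound 1 `CC1CCN(C2CCN(S(=O)(=O)c3ccc(C#N)cc3)CC2)CC1`: 2800 nM
compound 2 `CC1CCN(C2CCN(S(=O)(=O)c3nccn3C)CC2)CC1`: a limit of the assay, > 5000 nM
compound 3 `CC1CCN(C2CCN(S(=O)(=O)c3ccc(Cl)cc3Cl)CC2)CC1`: 1 nM

Compound 3 stands lowest of the numbers shown: a 2800-fold lower number from compound 1 to compound 3 (3.45 log units; beyond the scatter), and an at least 5000-fold lower number from compound 2 to compound 3 (3.69 log units; beyond the scatter). The value of compound 2 is a limit only (the limit of > 5000 nM in this assay, at which 1 of the 3 values shown sits). Compound 4 `CC1CCN(C2CCN(S(=O)(=O)c3cccnc3)CC2)CC1` differs from compound 3 by pyridin-3-yl in place of 2,4-dichlorophenyl on a sulfonyl sulfur. The two measured steps that bear on this both show that changing the group on the sulfonyl sulfur away from 2,4-dichlorophenyl shifts this assay by a large amount, and compound 2, whose ring also carries nitrogen, sits at the limit. Compound 4 is therefore expected to show a large rise in number, a 3000-fold higher number from compound 3 to compound 4 (3.48 log units; beyond the scatter), with an estimate of 3000 nM and a range from 300 nM to 8000 nM.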

Compound 4, half-maximal inhibitory concentration: 2400 nM
For compound 4 the middle estimate is 1.3-fold (0.10 log units) above the measured one; low and high end bracket the measured number.
By their numbers in this assay, from the lowest: compound 3; then compounds 4 and 1 (each within the scatter of the next). At a limit, above all of these: compound 2.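

In this assay, the pyridin-3-yl group loses almost all of what the 2,4-dichlorophenyl group gives: a 2400-fold higher number from compound 3 to compound 4 (3.38 log units; beyond the scatter). It stands level with the 4-cyanophenyl group, a 1.2-fold lower number from compound 1 to compound 4 (0.07 log units; within the scatter), so a third replacement on the sulfonyl sulfur again fails to keep the low number of compound 3. Compound 2 gives only a limit, so an at least 2.0-fold lower number from compound 2 to compound 4 (0.31 log units; beyond the scatter) is a floor: the limit of > 5000 nM in this assay, at which 1 of the 4 values shown sits.

What the compounds shown leave open is whether the low number of compound 3 needs both chlorine atoms. A single chlorine or a plain phenyl group on the sulfonyl sulfur would bear on that.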